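Shortening the ether chain of an aromatase inhibitor

The source may report more compounds than this note shows. Statements on the series, on what has been measured and on what is new or still open speak of the compounds shown alone.

Two compounds share one core. Compound 1 `CCC(CC)Oc1cc([N+](=O)[O-])ccc1N(C)S(C)(=O)=O` and compound 2 `CCCCCCCCCOc1cc([N+](=O)[O-])ccc1N(C)S(C)(=O)=O` differ in the chain attached to the aromatic oxygen. In an assay on SK-BR-3 cells for inhibition of Aromatase (Homo sapiens) (a lower number here means a stronger inhibitor, a higher number a weaker inhibitor), compound 1 gives 230 nM. In this assay, for the measured compounds named here, compound 2 gives 3960 nM, the higher of the two numbers; compound 1 is its only neighbour, and the gap between them lies beyond the usual scatter of such measurements. Going by the values given here, no single-site step between measured compounds is available, so the two values can only be set side by side.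

Compound 3 `COc1cc([N+](=O)[O-])ccc1N(C)S(C)(=O)=O` is the next member. It differs from compound 2 by hydrogen in place of octyl on a saturated chain carbon bound to an oxygen on an aromatic ring. The longer chain of compound 2 goes with the higher of the two measured numbers, and compound 3 strips the chain back almost entirely. On that basis compound 3 is expected to come in lower than compound 2 in this assay, an expected step of a 6.6-fold lower number from compound 2 to compound 3 (0.82 log units; beyond the scatter), although the two measured points cannot show whether a very short chain matches compound 1. The estimate for compound 3 in this assay is 600 nM, with a range from 120 nM to 3500 nM.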

Compound 3, half-maximal inhibitory concentration: > 25000 nM
Compound 3: only a limit was reported; the forecaster's own chance of this, stated with the estimate: 5%; at least 41-fold (1.61 log units) between middle value and limit.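

In this assay, hydrogen in place of octyl on a saturated chain carbon bound to an oxygen on an aromatic ring gives an at least 6.3-fold higher number from compound 2 to compound 3 (0.80 log units; beyond the scatter), so at this position a shorter chain does not by itself bring a lower number. Methyl in place of pentan-3-yl on an oxygen on an aromatic ring gives an at least 100-fold higher number from compound 1 to compound 3 (2.03 log units; beyond the scatter), which shows that the group on this oxygen can move the number a long way and that the pentan-3-yl group of compound 1 stands far ahead of the methyl group of compound 3. Compound 3 carries only a limit, so both steps give minimum sizes, and the three compounds together show no steady trend with chain length: the limit of > 25000 nM in this assay, at which 1 of the 3 values shown sits.

From the compounds shown here alone, what remains open is where between the methyl group and the longer chains the number starts to fall, and whether an ethyl, a propyl or a straight pentyl chain would match the pentan-3-yl group of compound 1. Also open, going by these compounds, is how a cyclopentyl ring or a chain ending in an amine on this oxygen would behave.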